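The compounds below may be only part of what the source reports. "The series", "measured", "known", "first", "only" and "open" are said of these compounds alone.

Compound 1 `CC1CC/C(=N\Nc2ccc(C(F)(F)F)cc2)c2ncc(C(=O)O)c(=O)n21` was tested in a functional assay on the whole organism for inhibition, with Rattus norvegicus as the target; a lower number here means that less compound is needed, a higher number that more compound is needed for the effect. In this assay compound 1 reaches only the limit of > 1000 umol/kg, so no number is known for it. Compound 2 `CC(=O)c1cccc(N/N=C2\CCC(C)n3c2ncc(C(=O)O)c3=O)c1` likewise gives only the limit of > 1000 umol/kg. Both values sit at the limit of > 1000 umol/kg in this assay, at which 2 of the 2 values shown sit. Compound 3 `CC1CC/C(=N\Nc2ccc(-c3ccccc3)cc2)c2ncc(C(=O)O)c(=O)n21` differs from compound 1 by phenyl in place of trifluoromethyl on an aromatic carbon. For the measured compounds named here, since no measured pair shows what such a change does here, the step is expected to be small, with no clear direction beyond the scatter, and compound 3 is likely to end at a limit as well. Compound 3 is expected at about 2000 umol/kg, within 700 umol/kg to 10000 umol/kg, a step that the limit leaves unreadable from compound 1 to compound 3.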

Compound 3, dose for 50% inhibition: > 100 umol/kg
Compound 3: no number, only a limit; the forecaster's own chance of this, stated with the estimate: 85%; the middle value does not contradict the limit.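

For the compounds shown here, compound 1 and compound 3 give only limits in this assay, and no step between the two can be read. Going by these compounds, it remains open whether trifluoromethyl or phenyl needs less compound for the effect.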